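Replacing the amide substituent of compound 1

This account rests on a few compounds, and the source may have more. Where it says the series, first, only, none or still open, it means among the compounds named here.

In an ADME assay on MT4 cells (Homo sapiens) for cytotoxicity, read by MTT assay, with a stated time of 5 days (on this read-out higher numbers stand for lower toxicity in this test and lower numbers for higher toxicity in this test), compound 1 `Cc1cc(C)cc(S(=O)(=O)c2c(C(=O)N[C@@H]3CCN(Cc4cccnc4)C3)[nH]c3ccc(Cl)cc23)c1` gives 36500 nM, the lowest number shown. Compound 2 `Cc1cc(C)cc(S(=O)(=O)c2c(C(=O)N[C@H]3CCN(Cc4ccccc4F)C3)[nH]c3ccc(Cl)cc23)c1` gives 215000 nM. The gap between these two compounds lies beyond the scatter. Compound 3 `Cc1cc(C)cc(S(=O)(=O)c2c(C(=O)N[C@H]3CCN(Cc4ccccc4C#N)C3)[nH]c3ccc(Cl)cc23)c1` gives > 228000 nM, which is a limit of the assay. Next comes compound 4 `Cc1cc(C)cc(S(=O)(=O)c2c(C(=O)NC3CN(S(C)(=O)=O)C3)[nH]c3ccc(Cl)cc23)c1`, with the change (1-(methylsulfonyl)azetidin-3-yl in place of 1-((pyridin-3-yl)methyl)pyrrolidin-3-yl on an amide-type nitrogen). Among the measured compounds shown here, the only measured step, an at least 1.0-fold higher number from compound 2 to compound 3 (0.02 log units; that floor lies within the scatter), is cyano in place of fluoro and leaves the group on the amide-type nitrogen unreplaced, so it bears only weakly. The reference for an upward move is compound 2 at 215000 nM. The expected change is a 3.0-fold higher number from compound 1 to compound 4 (0.48 log units; beyond the scatter), towards a higher number. For compound 4 the estimated value is 110000 nM, with an expected range of 35000 nM to 250000 nM.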

Compound 4, half-maximal cytotoxic concentration: > 252000 nM
Compound 4: a limit, no number; the forecaster's own chance of this, stated with the estimate: 25%; middle value at least 2.2-fold (0.36 log units) from the limit.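

Exchanging the group on the amide-type nitrogen gives a clear move in this assay, with 1-(methylsulfonyl)azetidin-3-yl in place of 1-((pyridin-3-yl)methyl)pyrrolidin-3-yl: an at least 6.9-fold higher number from compound 1 to compound 4 (0.83 log units; beyond the scatter). Compound 4 gives > 252000 nM, which is a limit of the assay. From the compounds shown here alone, the full size of the step stays unknown because the reading stops at that limit: the limit of > 252000 nM in this assay, at which 1 of the 4 values shown sits.

The step exchanges the whole group at once, so no single part of it can be singled out. Open, going by these compounds, is how a free amine or an acetyl on the azetidine nitrogen would read here.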